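The source may report more compounds than this note shows. Statements on the series, on what has been measured and on what is new or still open speak of the compounds shown alone.

Measured in a physicochemical assay for lipophilicity, read by HPLC, with a stated time of 90 min, tested at 100 uM; a higher number here means a more lipophilic compound, a lower number a more polar compound:
- compound 1 `O=C(Nc1ccc(C(F)(F)F)cc1)NC1CCN(C(=O)C2=COCC2)CC1`: 3.37
- compound 2 `O=C(Nc1ccc(OC(F)(F)F)cc1)NC1CCN(C(=O)c2cc[nH]c2)CC1`: 3.34
- compound 3 `O=C(Nc1ccc(OC(F)(F)F)cc1)NC1CCN(C(=O)C2=COCC2)CC1`: 3.49

Compound 1 stands second highest of the three numbers. Compound 2 lies nearest to it, and since the two values sit within the scatter of each other no order between compound 1 and compound 2 can be read. Compound 3 is the furthest, with a number 0.12 log units higher from compound 1 to compound 3 (within the scatter), still within the scatter.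

The next compound, compound 4 `Cc1occc1C(=O)N1CCC(NC(=O)Nc2ccc(C(F)(F)F)cc2)CC1`, is not yet measured in this assay. Its change from compound 1 is a group of 6 heavy atoms (5 carbon, 1 oxygen; one five-membered aromatic ring with 1 hetero atom) in place of a group of 5 heavy atoms (4 carbon, 1 oxygen; one five-membered non-aromatic ring with 1 hetero atom), on a carbonyl carbon. Within the data shown here, one measured step bears on it, the other exchange on the same carbonyl carbon: a number 0.15 log units higher from compound 2 to compound 3 (within the scatter), within the scatter. Among the measured compounds shown here, that step swapped a five-membered aromatic ring for a five-membered non-aromatic one; the step to compound 4 runs the other way and also brings in one more heavy atom, for which no measured pair gives a guide. A small step, if any, is therefore expected for compound 4, a number 0.23 log units higher from compound 1 to compound 4 (within the scatter), most likely not beyond the scatter. For compound 4 the expected value in this assay is 3.6, with a range from 3.3 to 3.9.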

Compound 4, partition coefficient: 4.19
Estimate against measurement, compound 4: 0.59 log units below; measured number above the stated range.
By their numbers in this assay, from the lowest: compounds 2, 1 and 3 (each within the scatter of the next); then compound 4.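

On the carbonyl carbon whose other neighbour is the amide-type nitrogen in a ring, 2-methylfuran-3-yl in place of the five-membered non-aromatic ring gives in this assay a number 0.82 log units higher from compound 1 to compound 4 (beyond the scatter) and so the first step in the series shown that lies beyond the scatter. Among these compounds, the earlier exchange at this place, a number 0.15 log units higher from compound 2 to compound 3 (within the scatter) on the trifluoromethoxy side, gave no readable change, so compound 4 is the first sign that the group on this carbonyl carbon can move the number at all. Nothing at hand bears on why this exchange moves the number so much more than the earlier one.

The step changes two things at once, the aromatic ring and the added methyl, and an unsubstituted furan ring on the same carbonyl carbon would show how much of it belongs to each. Also open, as far as these compounds go, is whether 2-methylfuran-3-yl gives a step of similar size with trifluoromethoxy in place of trifluoromethyl on the aromatic carbon, and how the number responds to a ring carrying an amine or a carboxylic acid at this place.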